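Cytotoxicity of a Fluorobenzyl Variant on Liver Cells

The source may hold more compounds than are shown below. What is called first, only, known or untested is meant among the compounds shown, and "the series" means these compounds.

Two compounds sharing one core were tested in an ADME assay on Huh-7 cells (Homo sapiens) for cytotoxicity, with a stated time of 72 h; on this read-out lower numbers stand for higher toxicity in this test and higher numbers for lower toxicity in this test. Compound 1 `CC(C)CCn1nc(CC2=CCCC2)c(O)c(C2=NS(=O)(=O)c3cc(NS(C)(=O)=O)ccc3N2)c1=O` gives > 33000 nM, which is a limit of the assay rather than a measured number. Compound 2 `COC(C)(C)CCn1nc(-c2cccs2)c(O)c(C2=NS(=O)(=O)c3cc(NS(C)(=O)=O)ccc3N2)c1=O` likewise gives > 33000 nM, again a limit of the assay and not a number. Among the measured compounds shown here, compound 2 thus stands at the upper edge of what this assay can report, as does the only other value shown, because of the limit of > 33000 nM in this assay, at which 2 of the 2 values shown sit. Compound 3 `CS(=O)(=O)Nc1ccc2c(c1)S(=O)(=O)N=C(c1c(O)c(-c3cccs3)nn(Cc3ccc(F)cc3)c1=O)N2` has not yet been measured. It differs from compound 2 in one place: 4-fluorophenyl in place of 2-methoxy-2-methylpropyl on a saturated chain carbon bound to an aromatic nitrogen. For the measured compounds named here, no measured step between two compounds is available for comparison, so the expectation rests on the two limits alone. The step that the limit leaves unreadable from compound 2 to compound 3 is expected to be no larger than the usual scatter, in no particular direction. Compound 3 is therefore estimated at 40000 nM, with a range from 15000 nM to 100000 nM.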

Compound 3, half-maximal cytotoxic concentration: > 1000 nM
Compound 3 was reported as a limit; the forecaster's own chance of this, stated with the estimate: 70%; the middle value does not contradict the limit.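

In this assay compound 3 gives > 1000 nM, which is a limit of the assay and not a number. Among the compounds shown here, compound 2 also carries only a limit, so no step from compound 2 to compound 3 can be read. Going by these compounds, whether 4-fluorobenzyl in place of 3-methoxy-3-methylbutyl changes the toxicity to these cells stays open.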